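Swapping a Ring for a Heptyl Chain

The source may report more compounds than this note shows. Statements on the series, on what has been measured and on what is new or still open speak of the compounds shown alone.

Three related compounds have been tested in an ADME assay on a cell-free system (plasma, Mus musculus) for metabolic stability, read by LC-MS, with a stated time of 1 h, tested at 10 uM; a lower number here means that less of the compound is left, a higher number that more of the compound is left. Compound 2 `CC(=O)NCCCC[C@H](NC(=O)[C@@H]1Cc2ccccc2CN1)C(=O)N[C@@H](CCC(=O)C=[N+]=[N-])C(=O)OC(C)C` gives 0%, and compound 3 `CC(=O)NCCCC[C@H](NC(=O)[C@@H]1Cc2ccccc2CN1C(C)=O)C(=O)N[C@@H](CCC(=O)C=[N+]=[N-])C(=O)OC(C)C` gives 0%, so these two sit level as the lowest of the three numbers. Compound 1 `CCCCCCCCCCCCCCCC(=O)N[C@@H](CCCCNC(C)=O)C(=O)N[C@@H](CCC(=O)C=[N+]=[N-])C(=O)OC(C)C` stands well clear of them at 30%.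

The next compound to be tested is compound 4 `CCCCCCCC(=O)N[C@@H](CCCCNC(C)=O)C(=O)N[C@@H](CCC(=O)C=[N+]=[N-])C(=O)OC(C)C`, which differs from compound 2 in one place: heptyl in place of 1,2,3,4-tetrahydroisoquinolin-3-yl on a carbonyl carbon. Put simply, this is heptyl in place of 1,2,3,4-tetrahydroisoquinolin-3-yl on a carbonyl carbon. Within the data shown here, only one measured step touches that ring: acetyl in place of hydrogen on an amine nitrogen in a ring gave no change at the digits printed from compound 2 to compound 3 (within the scatter). That step keeps the ring in place and tells nothing about removing it.

The better guide is compound 1, which also carries an open chain rather than a ring on that carbonyl carbon and gives 30%. Its chain is not the heptyl of compound 4, however, so that number is only a loose pointer. Compound 2 has nothing left to lose, which leaves upward as the only possible direction. A moderate rise is expected, a number 15 percentage points higher from compound 2 to compound 4 (beyond the scatter). The estimate for compound 4 is 15%, with an expected range from 0% to 35%.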

Compound 4, percent of the compound remaining: 0%
Estimate against measurement, compound 4: 15 percentage points above; measured number inside the range.
By their numbers in this assay, from the lowest: compounds 2, 3 and 4 (each within the scatter of the next); then compound 1.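

In this assay, an open chain on this carbonyl carbon is not enough on its own to leave any compound behind: heptyl in place of 1,2,3,4-tetrahydroisoquinolin-3-yl gives no change at the digits printed from compound 2 to compound 4 (within the scatter), so the ring and heptyl cannot be told apart here. The step that does register lies along the chain itself, where hydrogen in place of octyl, seven bonds along the chain from a carbonyl carbon, gives a number 30 percentage points lower from compound 1 to compound 4 (beyond the scatter), and of the compounds shown, only compound 1, with the longest chain, has a reading above the bottom of the scale. Nothing at hand explains why the longer chain goes with more compound remaining.

Compounds 2, 3 and 4 all sit at the bottom of the scale, so a single reading at the stated time cannot show whether they disappear at different speeds. Also open, on these data alone, is where along the chain the reading starts to rise, which a decyl or a dodecyl chain on the same carbonyl carbon would help to place, and whether a cyclohexyl group there would behave like heptyl.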